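The source may report more compounds than this note shows. Statements on the series, on what has been measured and on what is new or still open speak of the compounds shown alone.

The measured compounds and their values:
compound 1, `CCC/C=C/C(=O)N(Cc1ccc(OC)c(O)c1)c1cc(OC)c(OC)c(OC)c1`, 57 nM
compound 2, `COc1ccc(CNc2cc(OC)c(OC)c(OC)c2)cc1Br`, 39800 nM
compound 3, `C/C=C/C(=O)N(Cc1ccc(OC)c(Br)c1)c1cc(OC)c(OC)c(OC)c1`, 10500 nM

All three were tested in a functional assay on KYSE-450 cells (Homo sapiens) for inhibition, read by MTT assay, with a stated time of 48 h; a higher number here means a weaker inhibitor, a lower number a stronger inhibitor. Compound 1 stands lowest of the three numbers; the nearest of the others is compound 3 and the furthest is compound 2, and both gaps lie beyond the scatter. Among the compounds with values here, the only single-place step among the measured compounds is a 3.8-fold lower number from compound 2 to compound 3 (0.58 log units; beyond the scatter), in which (prop-1-en-1-yl)carbonyl takes the place of hydrogen on the nitrogen on the aromatic ring.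

Compound 4, `COc1ccc(CN(C(=O)/C=C/CBr)c2cc(OC)c(OC)c(OC)c2)cc1O`, is built from compound 1 by one change: bromo in place of ethyl on a saturated chain carbon bound to a double-bonded chain carbon. Within the data shown here, no measured step touches this part of the chain. The step from compound 2 to compound 3 concerns the acyl group on nitrogen as a whole, and compounds 1 and 3 differ from each other in more than one place, so their two values show only a wide gap without attributing it to any one change. With nothing to lean on, a step of at most modest size is expected in this assay, in either direction. Compound 4 is therefore estimated at 120 nM, within 25 nM to 600 nM, which corresponds to an expected step of a 2.1-fold higher number from compound 1 to compound 4 (0.32 log units; beyond the scatter).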

Compound 4, half-maximal inhibitory concentration: 100 nM
For compound 4 the middle estimate is 1.2-fold (0.08 log units) above the measured one; the range from low to high includes it.
By their numbers in this assay, from the lowest: compounds 1 and 4 (each within the scatter of the next); then compound 3; then compound 2.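

In this assay the exchange gives a 1.8-fold higher number from compound 1 to compound 4 (0.24 log units; within the scatter) and so lies within the scatter: on the core of compound 1, this saturated chain carbon bound to a double-bonded chain carbon can carry bromo in place of ethyl with no difference that can be told apart in this read-out. Within the data shown here, the earlier compounds could not show this, as their only single-place step concerned the acyl group on nitrogen as a whole, whereas the new pair isolates the difference between (pent-1-en-1-yl)carbonyl and (3-bromoprop-1-en-1-yl)carbonyl. Nothing measured here bears on why the two compounds read alike.

On the core of compound 1, the compounds shown cover only ethyl and bromo at this place, leaving open how chloro, hydroxy, a dimethylamino group or a longer chain would read there. They also leave open whether the likeness of compound 1 and compound 4 in this assay carries over to other cell lines or to longer exposure times.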